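Hydroxyphenyl position in a three-aryl pyridine series

This account rests on a few compounds, and the source may have more. Where it says the series, first, only, none or still open, it means among the compounds named here.

Measured compounds, with values in an assay on isolated protein for inhibition of DNA topoisomerase 1 (Homo sapiens), with a stated time of 30 min, tested at 100 uM; on this read-out lower numbers stand for a weaker effect and higher numbers for a stronger effect at the one concentration tested:
compound 1 `Oc1cccc(-c2cc(-c3cccs3)cc(-c3ccccc3O)n2)c1` gives 83.2%
compound 2 `Oc1cccc(-c2cc(-c3cccs3)cc(-c3cccc(O)c3)n2)c1` gives 91.7%
compound 3 `Oc1ccccc1-c1cc(-c2ccccn2)cc(-c2ccccc2O)n1` gives 0.8%

Compound 1 and compound 2 differ in one place, described as 3-hydroxyphenyl in place of 2-hydroxyphenyl on an aromatic carbon. The step that this change made in this assay is a number 8.5 percentage points higher from compound 1 to compound 2 (within the scatter), so the two hydroxyphenyl arrangements are not separated by the measurement here.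

Compound 3 stands apart: its number in this assay is the lowest of the three, and the gaps to compound 1 and compound 2 lie beyond the scatter. The difference between the core of compound 3 and the core of compound 1 is not broken down here.

Compound 4 `Oc1cccc(-c2cc(-c3ccccn3)cc(-c3ccccc3O)n2)c1` has not been measured in this assay. It differs from compound 3 by 3-hydroxyphenyl in place of 2-hydroxyphenyl on an aromatic carbon. Among the measured compounds shown here, this is the same kind of change as the one from compound 1 to compound 2, but the surroundings differ: in the first pair the place is meta to a 3-hydroxyphenyl group and meta to a thiophen-2-yl group, in the second pair meta to a 2-hydroxyphenyl group and meta to a pyridin-2-yl group.

For compound 4 the step from compound 3 is expected to be small, around a number 5.2 percentage points higher from compound 3 to compound 4 (within the scatter), because the same kind of change gave a number 8.5 percentage points higher from compound 1 to compound 2 (within the scatter). Compound 4 is therefore estimated at 6% in this assay, with a range from 0% to 28%. The low starting number of compound 3 is the main reason a near-zero read-out is expected, and a single precedent on a different core makes the range wide.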

Compound 4, a percentage reported as inhibition, at one concentration (the size of the read-out at that concentration, not a potency): 35.4%
Beside the measured number, compound 4's estimate is 29.4 percentage points below it; the measured number lies above the stated range.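

In this assay, 3-hydroxyphenyl in place of 2-hydroxyphenyl does not give a step of one size on both cores: the same change on two cores in this assay, a number 8.5 percentage points higher (within the scatter) from compound 1 to compound 2 and a number 34.6 percentage points higher (beyond the scatter) from compound 3 to compound 4, 26.1 percentage points apart, beyond the scatter of two such steps. On the core of compound 3 the change is large, a number 34.6 percentage points higher from compound 3 to compound 4 (beyond the scatter), and with the hydroxyphenyl groups held fixed, pyridin-2-yl in place of thiophen-2-yl is also large, a number 47.8 percentage points lower from compound 1 to compound 4 (beyond the scatter), so the step read on one core cannot simply be transferred to the other in this series. Among the compounds shown here, this does not show why the two steps differ, and with only one pair on each core it sets no rule for other cores, nor does it give a potency, since each number is a read-out at one concentration.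

On these data alone, it remains open whether a compound with pyridin-2-yl and two 3-hydroxyphenyl groups would keep the lower level of compound 4 or come close to compound 2, which would show how far the thiophen-2-yl group accounts for the high numbers. Also open, as far as these compounds go, is how this assay would respond to an amine or a carboxylic acid in place of the hydroxyl on these phenyl rings.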